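Replacing the aryl group on a weak inhibitor

The source may hold more compounds than are shown below. What is called first, only, known or untested is meant among the compounds shown, and "the series" means these compounds.

Measured so far in a functional assay on HeLa cells (Homo sapiens) for antiproliferative activity, read by MTT assay, with a stated time of 72 h; on this read-out higher numbers stand for weaker inhibition and lower numbers for stronger inhibition:
- Compound 1 `COc1ccc(-c2c(C(=O)c3cc(OC)c(OC)c(OC)c3)sc3ccccc23)cc1` gives 4200 nM
- Compound 2 `COc1ccc(-c2c(C(=O)c3cc(OC)c(OC)c(OC)c3)sc3ccccc23)cc1C` gives 10000 nM

Of these two numbers, compound 2 has the higher, 10000 nM, so it is the weaker inhibitor of the pair. Compound 3 `COc1cc(C(=O)c2sc3ccccc3c2Nc2ccc(Cl)cc2)cc(OC)c1OC` keeps the rest of compound 2 but makes a much larger change ((4-chlorophenyl)amino in place of 4-methoxy-3-methylphenyl on an aromatic carbon), with (4-chlorophenyl)amino in place of 4-methoxy-3-methylphenyl on an aromatic carbon.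

Going by the values given here, only one measured step bears on this, and only loosely. The modest change a 2.4-fold higher number from compound 1 to compound 2 (0.38 log units; beyond the scatter) came from methyl in place of hydrogen on an aromatic carbon. The methyl leaves again in compound 3, so compound 1 at 4200 nM offers a rough guide. Among the compounds with values here, no measured compound carries the amino link or the chlorine, so the data say little about the new group. An estimated change of modest size, a 2.5-fold lower number from compound 2 to compound 3 (0.40 log units; beyond the scatter), is therefore expected toward a lower number in this assay, though with low confidence. The estimate for compound 3 is 4000 nM, with an expected range from 500 nM to 20000 nM in this assay once it is measured.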

Compound 3, half-maximal inhibitory concentration: 3700 nM
Estimate against measurement, compound 3: 1.1-fold (0.03 log units) above; measured number inside the range.
By their numbers in this assay, from the lowest: compounds 3 and 1 (each within the scatter of the next); then compound 2.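

At this position, an aromatic carbon of a five-membered aromatic ring with 1 sulfur, the aryl group need not be joined directly to the ring: (4-chlorophenyl)amino can stand in place of 4-methoxy-3-methylphenyl, adding a hydrogen-bond donor, with no loss in this assay and in fact a 2.7-fold lower number from compound 2 to compound 3 (0.43 log units; beyond the scatter). Measured against the group without the methyl, the same kind of swap gives a 1.1-fold lower number from compound 1 to compound 3 (0.06 log units; within the scatter), so compound 3 only draws level with compound 1 and the gain seen from compound 2 takes the series no further than compound 1 had already reached. Nothing at hand explains why this quite different group reads so much like the 4-methoxyphenyl group.

The amino link and the chlorine arrive together in compound 3, so the compounds shown do not tell how much each contributes to the number. On these data alone, how this assay would respond to a plain phenylamino group, to a 4-methoxyphenylamino group, or to an oxygen atom as the link in place of the amino nitrogen also stays open.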